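A few compounds are considered here, and "the series" means these few. Any claim that something is new, unique, unknown or untested is made for them only; others in the source may bear on it.

In a physicochemical assay for solubility, read by HPLC, in phosphate buffer, with a stated time of 16 h, at pH 6.8 (on this read-out lower numbers stand for lower solubility and higher numbers for higher solubility), compound 1 (`COc1ccc([C@H](C)NC(=O)Cn2nnc3ccccc3c2=O)cc1`) gives 15000 nM and compound 2 (`Cc1ccc([C@H](C)NC(=O)Cn2nnc3ccccc3c2=O)cn1`) gives 9800 nM. Among the compounds with values here, these are the only two numbers so far, and they lie within the usual scatter of each other, as the measured step shows: a 1.5-fold lower number from compound 1 to compound 2 (0.18 log units; within the scatter). Compound 3 (`C[C@H](NC(=O)Cn1nnc2ccccc2c1=O)c1ccc(OC(F)F)cc1`) keeps everything in compound 1 except one group: difluoromethyl in place of methyl on an oxygen on an aromatic ring. Put simply, methoxy becomes difluoromethoxy. Within the data shown here, the one measured step replaces the whole group that carries the methoxy, so it bears on this change only indirectly, and no measured step tests the change itself. A step within the scatter is therefore expected, with a slight lean to a lower number. The expected step is a 1.5-fold lower number from compound 1 to compound 3 (0.18 log units; within the scatter). Compound 3 is estimated at 10000 nM, with an expected range from 4000 nM to 20000 nM.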

Compound 3, solubility: 2400 nM
The estimate for compound 3 lay 4.2-fold (0.62 log units) above the measured number, outside the stated range (below it).
By their numbers in this assay, from the lowest: compound 3; then compounds 2 and 1 (each within the scatter of the next).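

In this assay, replacing methoxy with difluoromethoxy gives a 6.3-fold lower number from compound 1 to compound 3 (0.80 log units; beyond the scatter). Unlike the step from compound 1 to compound 2, this one lies beyond the scatter, so the number responds clearly at this position. The oxygen stays on the aromatic ring and only the methyl becomes difluoromethyl, which shows that a change confined to this small group is enough to move the number, though nothing shown accounts for the fall. This is still a single pair, so it cannot show whether the fall follows from adding fluorine or would appear with other groups on that oxygen. Compounds carrying trifluoromethyl or ethyl on the oxygen, or an amine on the aromatic ring in its place, would help to separate these possibilities.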